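A Dimethylamino Chain in Place of the Triazole Diol

The compounds below may be only part of what the source reports. "The series", "measured", "known", "first", "only" and "open" are said of these compounds alone.

Compound 1 `CN1CCN(CCCCCCn2c3c(c4ccccc42)C(=O)c2c[n+]([O-])c4ccccc4c2C3=O)CC1`: 630 nM
Compound 2 `O=C1c2c[n+]([O-])c3ccccc3c2C(=O)c2c1c1ccccc1n2Cc1cn(C[C@@H](O)CO)nn1`: 140 nM
Compound 3 `CC1(C)OCC(Cn2cc(Cn3c4c(c5ccccc53)C(=O)c3c[n+]([O-])c5ccccc5c3C4=O)nn2)O1`: 330 nM

All three measured compounds share one core and differ only in the group attached on a saturated chain carbon bound to an aromatic nitrogen. In a functional assay on A-375 cells (Homo sapiens) for cytotoxicity, read by MTT assay, with a stated time of 72 h (on this read-out higher numbers stand for weaker inhibition and lower numbers for stronger inhibition), compound 2 gives the lowest number of the three. Its nearest neighbour is compound 3, reached by a 2.4-fold higher number from compound 2 to compound 3 (0.37 log units; beyond the scatter); the furthest is compound 1, from which compound 2 is reached by a 4.5-fold lower number from compound 1 to compound 2 (0.65 log units; beyond the scatter).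

Compound 4 `CN(C)CCCCCn1c2c(c3ccccc31)C(=O)c1c[n+]([O-])c3ccccc3c1C2=O` is not yet measured. It differs from compound 2 as follows: 4-(dimethylamino)butyl in place of 1-(2,3-dihydroxypropyl)-1H-1,2,3-triazol-4-yl on a saturated chain carbon bound to an aromatic nitrogen. Among the compounds with values here, the measured step that bears most on this change is the one from compound 1 to compound 2, a 4.5-fold lower number from compound 1 to compound 2 (0.65 log units; beyond the scatter), in which a chain carrying an amine gave way to the triazole diol. The step from compound 2 to compound 4 runs in the opposite direction, so a higher number is expected in this assay, although the entering 4-(dimethylamino)butyl group is shorter than the chain of compound 1 and carries a different amine, which leaves the size uncertain. Compound 4 is therefore estimated at 400 nM, with a range from 150 nM to 1000 nM. This estimate means an expected step of a 2.9-fold higher number from compound 2 to compound 4 (0.46 log units; beyond the scatter).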

Compound 4, half-maximal inhibitory concentration: 560 nM
Compound 4: middle estimate off by 1.4-fold (0.15 log units), on the low side; low and high end bracket the measured number.
By their numbers in this assay, from the lowest: compound 2; then compounds 3, 4 and 1 (each within the scatter of the next).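

In this assay, replacing the (1-(2,3-dihydroxypropyl)-1H-1,2,3-triazol-4-yl)methyl group with 5-(dimethylamino)pentyl gives a 4.0-fold higher number from compound 2 to compound 4 (0.60 log units; beyond the scatter), so a second chain ending in an amine now stands apart from the triazole diol, as compound 1 already did. The two amine chains cannot be told apart here: dimethylamino in place of (4-methylpiperazin-1-yl)methyl gives a 1.1-fold lower number from compound 1 to compound 4 (0.05 log units; within the scatter), so for these two compounds the kind of amine at the chain end makes no difference that rises above the scatter. Nothing available here explains why the triazole diol gives the lower number.

The compounds shown leave open whether the lower number of compound 2 goes with the triazole ring, with its diol, or simply with the absence of an amine at the end of a long chain. A plain pentyl chain with no amine, or a pentyl chain ending in a hydroxyl group, would help to separate these possibilities on the shared core.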